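The source may report more compounds than this note shows. Statements on the series, on what has been measured and on what is new or still open speak of the compounds shown alone.

Compound 3 `CCCc1nc[nH]c1CN[C@@H]1C[C@@H]2C[C@H]([C@H]1C)C2(C)C` gives 200000 nM in an ADME assay on MDCK cells (Canis lupus familiaris) for cytotoxicity, read by MTT assay, with a stated time of 48 h; a higher number here means that more compound is tolerated, a lower number that less compound is tolerated. Compound 1 `Cc1nc[nH]c1CN[C@@H]1C[C@@H]2C[C@H]([C@H]1C)C2(C)C` gives 252000 nM and compound 2 `CCc1nc[nH]c1CN[C@@H]1C[C@@H]2C[C@H]([C@H]1C)C2(C)C` gives 180000 nM, so the three numbers sit close together, with the step of a 1.3-fold lower number from compound 1 to compound 3 (0.10 log units; within the scatter) and the step of a 1.1-fold higher number from compound 2 to compound 3 (0.05 log units; within the scatter) both inside the scatter. Compound 4 `CCCc1nc(-c2ccccc2)[nH]c1CN[C@@H]1C[C@@H]2C[C@H]([C@H]1C)C2(C)C` differs from compound 3 by phenyl in place of hydrogen on an aromatic carbon. Among the compounds with values here, no measured step speaks to this change: the step of a 1.4-fold lower number from compound 1 to compound 2 (0.15 log units; within the scatter) and the other two steps all alter the saturated chain, none adds a phenyl, and all stay within the scatter. With nothing in the data pointing either way, a step of a 1.5-fold lower number from compound 3 to compound 4 (0.19 log units; within the scatter) is expected. Compound 4 is estimated at 130000 nM, with a range from 45000 nM to 300000 nM.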

Compound 4, half-maximal cytotoxic concentration: 143000 nM
For compound 4 the middle estimate is 1.1-fold (0.04 log units) below the measured one; measured number inside the range.
By their numbers in this assay, from the lowest: compounds 4, 2, 3 and 1 (each within the scatter of the next).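

The earlier steps shown here only altered the saturated chain, whereas this one puts phenyl, with its 6 heavy atoms, on the aromatic carbon between two ring nitrogen atoms. In this assay this gives a 1.4-fold lower number from compound 3 to compound 4 (0.15 log units; within the scatter) and so, even with a group this large at this position, the number stays within the scatter. Nothing measured here gives a reason for this result.

On these data alone, whether an amine or a carboxylic acid on this carbon would also stay within the scatter remains open. So does whether phenyl gives the same result on the cores of compound 1 and compound 2.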